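This account rests on a few compounds, and the source may have more. Where it says the series, first, only, none or still open, it means among the compounds named here.

Three compounds share one core, and they differ only in the group attached to an aromatic carbon. Compound 1 `c1coc(-c2ccccc2NCC2=NCCN2)c1` gives 0.468 nM in a functional assay for activation of Alpha-1A adrenergic receptor (Homo sapiens), read by calcium flux; on this read-out lower numbers stand for an effect already at smaller amounts and higher numbers for an effect only at larger amounts of compound. Compound 2 `Cc1nc(-c2ccccc2NCC2=NCCN2)cs1` gives 4.47 nM in this assay, and compound 3 `c1csc(-c2ccccc2NCC2=NCCN2)c1` gives 2.24 nM. Compound 2 thus stands at the highest of the three numbers: the step of a 9.6-fold higher number from compound 1 to compound 2 (0.98 log units; beyond the scatter) lies beyond the scatter, while the step of a 2.0-fold lower number from compound 2 to compound 3 (0.30 log units; within the scatter) lies within it. Compound 4 `CC/C(=N\OC)c1ccccc1NCC1=NCCN1` has not been measured. It differs from compound 2 as follows: a group of 6 heavy atoms (4 carbon, 1 nitrogen, 1 oxygen; no ring) in place of a group of 6 heavy atoms (4 carbon, 1 nitrogen, 1 sulfur; one five-membered aromatic ring with 2 hetero atoms), on an aromatic carbon.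

The measured steps of a 9.6-fold higher number from compound 1 to compound 2 (0.98 log units; beyond the scatter) and a 4.8-fold higher number from compound 1 to compound 3 (0.68 log units; beyond the scatter) were both modest, and the step of a 2.0-fold lower number from compound 2 to compound 3 (0.30 log units; within the scatter) was within the scatter, but each of them exchanges one five-membered aromatic ring for another. Among the compounds with values here, none of them tests the loss of the ring for an open chain, so no measured step bears directly on this change. With that gap, the expectation for compound 4 is a small step of a 2.2-fold higher number from compound 2 to compound 4 (0.35 log units; beyond the scatter), with no direction beyond the scatter claimed. Compound 4 is therefore estimated at 10 nM, with a range from 2 nM to 50 nM.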

Compound 4, half-maximal effective concentration: 3.31 nM
The estimate for compound 4 lay 3.0-fold (0.48 log units) above the measured number; measured number inside the range.
By their numbers in this assay, from the lowest: compound 1; then compounds 3, 4 and 2 (each within the scatter of the next).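

In this assay, the open chain with no ring and one double bond outside aromatic rings sits level with two of the five-membered aromatic rings, with a 1.4-fold lower number from compound 2 to compound 4 (0.13 log units; within the scatter) and a 1.5-fold higher number from compound 3 to compound 4 (0.17 log units; within the scatter) both inside the usual scatter. Only the furan-2-yl group of compound 1 remains apart, with a 7.1-fold higher number from compound 1 to compound 4 (0.85 log units; beyond the scatter) beyond the scatter, so on this aromatic carbon a ring is not required to reach the level of compound 2 and compound 3, although none of these three reaches compound 1. No measurement shown here accounts for how the ring can be given up at this position.

From the compounds shown here alone, it remains open whether an amine or a carboxylic acid on this aromatic carbon would hold the same level. The same question stands for a longer chain, or for a saturated chain without the double bond.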